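A few compounds are considered here, and "the series" means these few. Any claim that something is new, unique, unknown or untested is made for them only; others in the source may bear on it.

In a functional assay on DLD-1 cells (Homo sapiens) for cytotoxicity, with a stated time of 48 h (a lower number here means a stronger inhibitor, a higher number a weaker inhibitor), compound 1 `CCCC(=O)Oc1ccc2oc(/C=C/[S+](C)[O-])cc(=O)c2c1` gives 8700 nM and stands within the scatter of compound 2 `COc1ccc2c(=O)cc(/C=C/[S+](C)[O-])oc2c1` at 7800 nM and of compound 3 `Cc1cccc2oc(/C=C/[S+](C)[O-])cc(=O)c12` at 5500 nM without separating from either. Compound 4 `C[S+]([O-])/C=C/c1cc(=O)c2cc(Cl)ccc2o1` differs from compound 1 by the change chloro in place of (propylcarbonyl)oxy on an aromatic carbon with chloro in place of (propylcarbonyl)oxy on an aromatic carbon. For the measured compounds named here, no pair of measured compounds isolates this change. With different groups on the shared core, compound 1 at 8700 nM and compound 3 at 5500 nM stay within the scatter of each other, so no step beyond the scatter is expected in this assay in either direction. The estimated step of a 1.3-fold lower number from compound 1 to compound 4 (0.13 log units; within the scatter) is therefore expected to be small. Compound 4 is estimated at 6500 nM (expected range 3000 nM to 14000 nM).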

Compound 4, half-maximal inhibitory concentration: 6500 nM
Compound 4: the middle estimate sits on the measured number at the digits printed, and the stated range covers the measured number.
By their numbers in this assay, from the lowest: compounds 3, 4, 2 and 1 (each within the scatter of the next).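

In this assay, for the compounds shown here, the step at this position, a 1.3-fold lower number from compound 1 to compound 4 (0.13 log units; within the scatter), gives the first direct reading of a change on this aromatic carbon. Chloro, a single heavy atom without hydrogen-bond acceptors, stands where the six heavy atoms of (propylcarbonyl)oxy stood, yet the two compounds do not separate. No measured evidence accounts for this result. The compounds shown leave open whether an amine or a carboxylic acid on this carbon would produce a step beyond the scatter.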